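The source may hold more compounds than are shown below. What is called first, only, known or untested is meant among the compounds shown, and "the series" means these compounds.

Compound 1 `O=[N+]([O-])c1cc(C(F)(F)F)cc([N+](=O)[O-])c1Oc1ccc(Cl)cc1/C=N\OCc1ccccc1`: 3410 nM
Compound 2 `O=[N+]([O-])c1cc(C(F)(F)F)cc([N+](=O)[O-])c1Oc1ccc(Cl)cc1/C=N\OCc1ccccc1F`: 2570 nM
Compound 3 `O=[N+]([O-])c1cc(C(F)(F)F)cc([N+](=O)[O-])c1Oc1ccc(Cl)cc1/C=N\OCc1ccccc1Cl`: 5030 nM

These three compounds were tested in a functional assay on A549 cells (Homo sapiens) for antiproliferative activity, read by MTT assay, with a stated time of 48 h; on this read-out higher numbers stand for weaker inhibition and lower numbers for stronger inhibition. They share one core and differ only in the benzyl group. Compound 3, at 5030 nM, cannot be told apart from compound 1 or compound 2, since every step among the three lies within the normal scatter of repeated measurements.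

The next compound to be tested is compound 4 `O=[N+]([O-])c1cc(C(F)(F)F)cc([N+](=O)[O-])c1Oc1ccc(Cl)cc1/C=N\OCc1ccc(Cl)cc1Cl`. Among the measured compounds shown here, its only difference from compound 3 is chloro in place of hydrogen on an aromatic carbon, turning 2-chlorobenzyl into 2,4-dichlorobenzyl.

The closest guide is the same kind of swap, seen in a 1.5-fold higher number from compound 1 to compound 3 (0.17 log units; within the scatter). The step of a 1.3-fold lower number from compound 1 to compound 2 (0.12 log units; within the scatter) shows a fluoro in place of hydrogen, and a 2.0-fold higher number from compound 2 to compound 3 (0.29 log units; within the scatter) shows chloro in place of fluoro. All three steps are small, so they offer no reason to expect a real shift in this assay. For the measured compounds named here, that guidance is limited, as no measured compound carries the 2,4-dichlorobenzyl group.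

The expected result is therefore no change beyond the scatter, and the estimated step is a 1.3-fold lower number from compound 3 to compound 4 (0.10 log units; within the scatter). For compound 4 the estimated value is 4000 nM, with an expected range from 1800 nM to 8500 nM.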

Compound 4, half-maximal inhibitory concentration: 3440 nM
Compound 4: middle estimate off by 1.2-fold (0.07 log units), on the high side, within the range that was stated.
By their numbers in this assay, from the lowest: compounds 2, 1, 4 and 3 (each within the scatter of the next).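

In this assay, among the compounds shown here, the carbon para to a large group on the benzyl ring now carries a chloro for the first time, and adding it to the 2-chlorobenzyl group gives a 1.5-fold lower number from compound 3 to compound 4 (0.17 log units; within the scatter). The earlier compounds shown here held no more than one halogen on this ring, whereas compound 4 holds two chloro groups, yet the comparisons with them give a 1.3-fold higher number from compound 2 to compound 4 (0.13 log units; within the scatter) and a 1.0-fold higher number from compound 1 to compound 4 (0.00 log units; within the scatter). Across these four compounds, then, neither a single halogen nor the 2,4-dichlorobenzyl pattern has been seen to move the number beyond the scatter, so this new position behaves like the changes seen before it.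

No supporting measurement is available to explain why these changes leave the number so flat.

Going by these compounds, whether an amine, a carboxylic acid or a methoxy group on this same carbon would produce a real shift remains open, as does the effect of replacing the benzyl group with a longer chain.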